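Direct aryl versus benzyl on the shared core

This account rests on a few compounds, and the source may have more. Where it says the series, first, only, none or still open, it means among the compounds named here.

Measured compounds and their numbers:
compound 1 `C=C(Br)C(=O)Nc1cccc(-c2cn3nc(-c4ccc(F)cc4)sc3n2)c1`: 250 nM
compound 2 `C=C(Br)C(=O)Nc1cccc(-c2cn3nc(Cc4cccc(OC)c4)sc3n2)c1`: 2000 nM
compound 3 `C=C(Br)C(=O)Nc1cccc(-c2cn3nc(Cc4ccc(Cl)cc4)sc3n2)c1`: 2300 nM

All numbers come from a functional assay on L1210 cells (Mus musculus) for inhibition, read by cell counting, with a stated time of 2 days; on this read-out lower numbers stand for stronger inhibition and higher numbers for weaker inhibition. Compound 3 gives the highest number of the three; it lies within the scatter of compound 2 and well apart from compound 1. The two steps away from compound 1 look alike: an 8.0-fold higher number from compound 1 to compound 2 (0.90 log units; beyond the scatter) and a 9.2-fold higher number from compound 1 to compound 3 (0.96 log units; beyond the scatter), each replacing a phenyl bound straight to the core with a benzyl group. Between the two benzyl compounds, a 1.2-fold higher number from compound 2 to compound 3 (0.06 log units; within the scatter).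

Compound 4 `C=C(Br)C(=O)Nc1cccc(-c2cn3nc(-c4ccc(OC)c(OC)c4)sc3n2)c1` returns to a phenyl bound straight to the core: 3,4-dimethoxyphenyl in place of 4-chlorobenzyl on an aromatic carbon. Among the measured compounds shown here, the steps that bear on it are the two aryl-to-benzyl steps, both modest and beyond the scatter, and both run opposite to this change. For the measured compounds named here, no measured pair sets 3,4-dimethoxyphenyl against 4-fluorophenyl, so the weight of the methoxy pattern itself is unknown and the range must stay wide. The expectation is therefore a lower number for compound 4, roughly reversing a 9.2-fold higher number from compound 1 to compound 3 (0.96 log units; beyond the scatter). The estimated step is a 5.8-fold lower number from compound 3 to compound 4 (0.76 log units; beyond the scatter). For compound 4 the expected value is 400 nM, with a range of 150 nM to 1500 nM.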

Compound 4, half-maximal inhibitory concentration: 42 nM
The estimate for compound 4 lay 9.5-fold (0.98 log units) above the measured number; measured number below the stated range.
By their numbers in this assay, from the lowest: compound 4; then compound 1; then compounds 2 and 3 (each within the scatter of the next).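

In this assay, among the compounds shown here, substitution on a phenyl bound straight to the shared core carries weight of its own, with a 6.0-fold lower number from compound 1 to compound 4 (0.77 log units; beyond the scatter) for 3,4-dimethoxyphenyl in place of 4-fluorophenyl, whereas the only earlier comparison of substituents, between the two benzyl compounds, stayed within the scatter. For the compounds shown here, the position on the five-membered ring therefore spans a wider range than the earlier compounds showed, with a 55-fold lower number from compound 3 to compound 4 (1.74 log units; beyond the scatter) and a 48-fold lower number from compound 2 to compound 4 (1.68 log units; beyond the scatter) for the change from a benzyl group to 3,4-dimethoxyphenyl, although each of these two steps alters both the link to the core and the substituents on the ring, so they cannot be divided between the two changes. No evidence is available on why this position responds as it does.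

Still open, going by these compounds, is whether a 3,4-dimethoxybenzyl group would stay close to the other benzyl compounds or approach compound 4, which would separate the link from the substituents. Also open, on these data alone, is whether one methoxy group on the directly bound phenyl is enough, and how an amine or a carboxylic acid on that ring would read out.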